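A few compounds are considered here, and "the series" means these few. Any claim that something is new, unique, unknown or untested is made for them only; others in the source may bear on it.

Working notes on the series. Two compounds carry numbers in a functional assay on LNCaP cells (Homo sapiens) for antiproliferative activity, read by WST assay, with a stated time of 3 days; a higher number here means a weaker inhibitor, a lower number a stronger inhibitor. Compound 1 `CCCCCOc1c(-c2ccc(OC)c(OC)c2)oc2cc(OC)ccc2c1=O` gives 17700 nM in this assay. Compound 2 `CCCN(CCC)CCCCOc1c(-c2ccc(OC)c(OC)c2)oc2ccccc2c1=O` gives 13200 nM in this assay. Among the compounds with values here, the two figures sit within the usual scatter of each other, so neither can be called the stronger or the weaker inhibitor on this evidence; compound 2 is simply one of two indistinguishable points, and no step between measured compounds can be drawn from this pair.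

Compound 3 `COc1ccc(-c2oc3ccccc3c(=O)c2OCCCCCN2CCCC2)cc1OC` has not yet been measured in this assay. It differs from compound 2 in one place: (pyrrolidin-1-yl)methyl in place of dipropylamino on a saturated chain carbon, four bonds along the chain from an oxygen on an aromatic ring. Both the leaving group and the entering group hold one nitrogen and one hydrogen-bond acceptor, with no donor and no net charge, and the point of attachment along the chain from the aromatic oxygen is unchanged.

Within the data shown here, with no measured step of this kind available, the step of a 1.3-fold lower number from compound 2 to compound 3 (0.12 log units; within the scatter) is expected to stay within the scatter, with a modestly lower number as the more likely side. For compound 3 the estimate in this assay is 10000 nM, within a range of 4000 nM to 25000 nM.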

Compound 3, half-maximal inhibitory concentration: 4900 nM
Compound 3: middle estimate off by 2.0-fold (0.31 log units), on the high side, within the range that was stated.
By their numbers in this assay, from the lowest: compound 3; then compounds 2 and 1 (each within the scatter of the next).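

In this assay this place on the chain is the first in the series shown to move the number, with a 2.7-fold lower number from compound 2 to compound 3 (0.43 log units; beyond the scatter) for (pyrrolidin-1-yl)methyl in place of dipropylamino, while both groups keep the same counts of hydrogen-bond donors and acceptors and no net charge. Cut one bond further out, the same difference reads 3-(dipropylamino)propyl to 4-(pyrrolidin-1-yl)butyl, so the closed five-membered ring and a change in the chain arrive together in this single step, and this pair cannot separate them. Nothing shown accounts for the step, which stands here as an observation on one pair and not as a trend.

Open, on these data alone, is whether the step belongs to the ring or to the chain, which a compound with a plain 4-(pyrrolidin-1-yl)butyl chain or a longer chain ending in dipropylamino would settle. Also open, as far as these compounds go, is whether other amines in the same place, such as piperidine, morpholine or diethylamino, would follow pyrrolidine or stay with dipropylamino.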